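The source may report more compounds than this note shows. Statements on the series, on what has been measured and on what is new or still open speak of the compounds shown alone.

Working notes on the series. Compound 2 `CC1CCN(c2c(S(=O)(=O)c3ccc(C#N)cc3)cnc3ccc(F)cc23)CC1` is the reference; in an assay on isolated protein for displacement of a labelled ligand from metabotropic glutamate receptor 5 (Homo sapiens), with a stated time of 60 min, tested at 1 uM (a higher number here means more inhibition at the concentration tested (going by the name of the read-out), a lower number less inhibition), compound 2 gives 75%. Compound 1 `Cc1cc(C)cc(S(=O)(=O)c2cnc3ccc(F)cc3c2N2CCC(C)CC2)c1` differs from compound 2 by 3,5-dimethylphenyl in place of 4-cyanophenyl on a sulfonyl sulfur, and in this assay compound 1 gives 83%, the step being a number 8 percentage points higher from compound 2 to compound 1 (within the scatter). The core of compound 3 `CC1CCN(c2c(S(=O)(=O)c3ccc(C#N)cc3)cnc3ccc(Cl)cc23)CC1` differs from the core of compound 2 by chloro in place of fluoro on an aromatic carbon; in this assay compound 3 gives 31%, a step of a number 44 percentage points lower from compound 2 to compound 3 (beyond the scatter), leaving compound 3 lowest of the three measured.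

Compound 4 `Cc1cc(C)cc(S(=O)(=O)c2cnc3ccc(Cl)cc3c2N2CCC(C)CC2)c1` is not yet measured. It differs from compound 3 by 3,5-dimethylphenyl in place of 4-cyanophenyl on a sulfonyl sulfur. This is the same change as that made from compound 2 to compound 1, occurring twice among the compounds shown, and the place is worded identically in both pairs, so it counts as the same change. Among the measured compounds shown here, only one measured pair carries it, so the expectation rests on that pair alone. The step is expected to be a number 8 percentage points higher from compound 3 to compound 4 (within the scatter) because the same change earlier gave a number 8 percentage points higher from compound 2 to compound 1 (within the scatter). In this assay compound 4 is therefore expected to give about 39%, likely between 20% and 58%.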

Compound 4, a percentage reported as inhibition, at one concentration (the size of the read-out at that concentration, not a potency): 49%
For compound 4 the middle estimate is 10 percentage points below the measured one; measured number inside the range.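

In this assay, 3,5-dimethylphenyl in place of 4-cyanophenyl on a sulfonyl sulfur gives a number 18 percentage points higher from compound 3 to compound 4 (beyond the scatter), and this agrees with the earlier reading of the same change: the same change on two cores in this assay, a number 8 percentage points higher (within the scatter) from compound 2 to compound 1 and a number 18 percentage points higher (beyond the scatter) from compound 3 to compound 4, 10 percentage points apart, within the scatter of two such steps Chloro in place of fluoro on an aromatic carbon, read with 3,5-dimethylphenyl on the sulfonyl sulfur, gives a number 34 percentage points lower from compound 1 to compound 4 (beyond the scatter), and this change also carries over from one core to the other: the same change on two cores in this assay, a number 44 percentage points lower (beyond the scatter) from compound 2 to compound 3 and a number 34 percentage points lower (beyond the scatter) from compound 1 to compound 4, 10 percentage points apart, within the scatter of two such steps Across these four compounds, each change therefore behaves alike on both cores as far as the scatter can tell, but this rests on two pairs per change at a single concentration, so it shows neither a rule for other cores nor any difference in potency.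

As far as these compounds go, it remains open whether the same agreement holds with bromo or methoxy in place of chloro or fluoro on that aromatic carbon. The same question stands for a pyridyl ring or a carboxylic acid-bearing phenyl on the sulfonyl sulfur.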